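A few compounds are considered here, and "the series" means these few. Any claim that something is new, unique, unknown or untested is made for them only; others in the source may bear on it.

Compound 1 `COc1ccccc1Nc1nc(SCc2ccc(C(F)(F)F)cc2)nc2ccccc12` and compound 2 `CCOc1ccccc1Nc1nc(SCc2ccc(C(F)(F)F)cc2)nc2ccccc12` share their core with compound 3 `COc1ccc(Nc2nc(SCc3ccc(C(F)(F)F)cc3)nc3ccccc23)cc1` and with the unmeasured compound 4 `CCOc1ccc(Nc2nc(SCc3ccc(C(F)(F)F)cc3)nc3ccccc23)cc1`. In a functional assay on MDA-MB-231 cells (Homo sapiens) for cytotoxicity, read by MTT assay, with a stated time of 72 h (on this read-out lower numbers stand for stronger inhibition and higher numbers for weaker inhibition), compound 1 gives only a limit, > 50000 nM. Compound 2 likewise reaches only a limit, > 50000 nM. Compound 3 gives a number, 15700 nM, and the step of an at least 3.1-fold lower number from compound 1 to compound 3 (0.50 log units; beyond the scatter) comes with the difference (4-methoxyphenyl in place of 2-methoxyphenyl on a nitrogen on an aromatic ring); the step of an at least 3.1-fold lower number from compound 2 to compound 3 (0.50 log units; beyond the scatter) reads the same way. The change methyl in place of hydrogen on a saturated chain carbon bound to an oxygen on an aromatic ring gives the step that the two limits leave unreadable from compound 1 to compound 2, because the limit of > 50000 nM in this assay, at which 2 of the 3 values shown sit, hides its size. Compound 4 carries the same change, (methyl in place of hydrogen on a saturated chain carbon bound to an oxygen on an aromatic ring), on the core of compound 3, at the same place. With no readable precedent, the expected step of a 1.0-fold higher number from compound 3 to compound 4 (0.01 log units; within the scatter) is small. That expectation rests on compound 3 at 15700 nM. Compound 4 is therefore estimated at 16000 nM, between 6000 nM and 45000 nM.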

Compound 4, half-maximal inhibitory concentration: 23000 nM
For compound 4 the middle estimate is 1.4-fold (0.16 log units) below the measured one; the measured number falls inside the stated range.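

In this assay, methyl in place of hydrogen on the core of compound 3 gives a 1.5-fold higher number from compound 3 to compound 4 (0.17 log units; within the scatter), so on this core methoxy and ethoxy cannot be told apart. This single readable pair does not show that the change behaves alike on another core, and on the core of compound 1 its step cannot be read, because both values there are limits: the limit of > 50000 nM in this assay, at which 2 of the 4 values shown sit. The steps of an at least 2.1-fold lower number from compound 2 to compound 4 (0.33 log units; beyond the scatter) and an at least 2.1-fold lower number from compound 1 to compound 4 (0.33 log units; beyond the scatter) each start from a limit, so they give only a minimum size and go with the 4-ethoxyphenyl group.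

From the compounds shown here alone, how a longer chain such as propoxy would read at this place remains open. So does the effect of an amine or a carboxylic acid on that phenyl ring.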